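From 1H-imidazol-2-yl to 1,2,4-oxadiazol-3-yl: an unmeasured ring swap

The source may report more compounds than this note shows. Statements on the series, on what has been measured and on what is new or still open speak of the compounds shown alone.

In an in vivo ADME assay on the whole organism (strain 129/SvEvBrd x C57BL/6) for pharmacokinetics, with Mus musculus as the target (a lower number here means that a smaller share of the oral dose reaches the circulation, a higher number that a larger share of the oral dose reaches the circulation), compound 3 `OC[C@@H](O)[C@@H](O)[C@H](O)c1c[nH]c(-c2ncc[nH]2)n1` gives 28%. Compound 1 `CC(O)c1nc([C@@H](O)[C@H](O)[C@H](O)CO)c[nH]1` gives 22%, and compound 2 `OC[C@@H](O)[C@@H](O)[C@H](O)c1c[nH]c(-c2cscn2)n1` gives 12%. The data show a number 6 percentage points higher from compound 1 to compound 3 (within the scatter) and a number 16 percentage points higher from compound 2 to compound 3 (beyond the scatter), so only the second of these gaps stands clear of the noise.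

Compound 4 `OC[C@@H](O)[C@@H](O)[C@H](O)c1c[nH]c(-c2ncon2)n1` differs at one place, with 1,2,4-oxadiazol-3-yl in place of 1H-imidazol-2-yl on an aromatic carbon.

Among the measured compounds shown here, the one measured exchange of one ring for another on that carbon is a number 16 percentage points higher from compound 2 to compound 3 (beyond the scatter), a modest step that favours the ring compound 4 gives up. The step of a number 10 percentage points lower from compound 1 to compound 2 (within the scatter) adds little. With so few compounds, this supports only a tentative expectation of a small loss in this assay, not a firm direction. The expected change is a number 8 percentage points lower from compound 3 to compound 4 (within the scatter). Compound 4 is estimated at 20%, with an expected range from 8% to 34%.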

Compound 4, oral bioavailability: 5%
The estimate for compound 4 lay 15 percentage points above the measured number; measured number outside the range, below it.
By their numbers in this assay, from the lowest: compounds 4, 2, 1 and 3 (each within the scatter of the next, the first and the last beyond it).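

In this assay, among the compounds shown here, the change shows that the aromatic ring on this carbon can cost more than the earlier compounds suggested: a number 23 percentage points lower from compound 3 to compound 4 (beyond the scatter), and the new ring also stands clear of the open-chain 1-hydroxyethyl group, a number 17 percentage points lower from compound 1 to compound 4 (beyond the scatter). The two rings without the imidazole arrangement do not separate, however, as a number 7 percentage points lower from compound 2 to compound 4 (within the scatter). So 1H-imidazol-2-yl stands clear of 1,2,4-oxadiazol-3-yl but not of 1-hydroxyethyl, whose step to compound 3 lies within the scatter.

Nothing available explains why the oral share drops when the ring hydrogen-bond donor is lost and a ring oxygen enters. The compounds shown leave open whether an N-methylimidazole, which keeps the ring but lacks that hydrogen, or an amine on this carbon would follow compound 3 or compound 4.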